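Cytotoxicity at the assay limit: compound 3 to compound 4

This account rests on a few compounds, and the source may have more. Where it says the series, first, only, none or still open, it means among the compounds named here.

Compound 1 `CCOC(=O)c1c(-c2cccc(OC(F)(F)F)c2)[nH]c2cc(OC)c(F)cc2c1=O`: > 22000 nM, a limit
Compound 2 `CCOC(=O)c1c(-c2cccc(F)c2)[nH]c2cc(OC)c(F)cc2c1=O`: > 22000 nM, a limit
Compound 3 `CCOC(=O)c1c(-c2cccc(Oc3c(C)cccc3C)c2)[nH]c2cc(OC)c(F)cc2c1=O`: > 22000 nM, a limit

All three compounds were tested in an ADME assay on HEK293 cells (Homo sapiens) for cytotoxicity, read by luminescence, with a stated time of 72 h (a higher number here means that more compound is needed for the effect, a lower number that less compound is needed), and none gave a number: the limit of > 22000 nM in this assay, at which 3 of the 3 values shown sit. Compound 3 stands at > 22000 nM, which is a limit. Compound 4 `CCOC(=O)c1c(-c2cccc(Cc3nc(C)c(C)s3)c2)[nH]c2cc(OC)c(F)cc2c1=O` differs from compound 3 in one place: a group of 8 heavy atoms (6 carbon, 1 nitrogen, 1 sulfur; one five-membered aromatic ring with 2 hetero atoms) in place of a group of 9 heavy atoms (8 carbon, 1 oxygen; one six-membered aromatic ring of carbon only), on an aromatic carbon. For the measured compounds named here, three measured steps bear on this change: a step that the two limits leave unreadable from compound 2 to compound 3, at the same aromatic carbon, then a step that the two limits leave unreadable from compound 1 to compound 2 and a step that the two limits leave unreadable from compound 1 to compound 3. None has a readable size, so they support no expected direction. No shift beyond the scatter is expected in this assay. The expected result is a step that the limit leaves unreadable from compound 3 to compound 4. The estimated value for compound 4 is 25000 nM, with an expected range of 10000 nM to 50000 nM.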

Compound 4, half-maximal effective concentration: > 22000 nM
Compound 4: a limit, no number; the forecaster's own chance of this, stated with the estimate: 80%; the middle value lies beyond the limit too.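

For the compounds shown here, compound 4 stands at a limit, as do compound 1, compound 2 and compound 3, so no step to compound 4 from any of them can be read: the limit of > 22000 nM in this assay, at which 4 of the 4 values shown sit. The four compounds leave open how far apart their true values lie in this assay.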